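The source may report more compounds than this note shows. Statements on the series, on what has been measured and on what is new or still open speak of the compounds shown alone.

Compound 1 `COc1ccc(NC(=S)OCCNC(=O)C(C)(C)Oc2ccc(Cl)cc2)cc1`: 780000 nM
Compound 2 `CC(C)(Oc1ccc(Cl)cc1)C(=O)NCCOC(=S)Nc1ccc([N+](=O)[O-])cc1Cl`: > 800000 nM

Both compounds were tested in an ADME assay on WI-38 cells (Homo sapiens) for cytotoxicity, read by MTT assay, with a stated time of 48 h; a higher number here means a weaker inhibitor, a lower number a stronger inhibitor. Compound 2 stands at > 800000 nM, which is a limit of the assay and not a number.

Compound 3 `CC(C)(Oc1ccc(Cl)cc1)C(=O)NCCOC(=S)Nc1ccccc1` has not yet been measured. It differs from compound 2 in one place: phenyl in place of 2-chloro-4-nitrophenyl on an amide-type nitrogen.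

Going by the values given here, one measured step bears on this change, as it also replaced the group at this nitrogen: an at least 1.0-fold higher number from compound 1 to compound 2 (0.01 log units; that floor lies within the scatter). Only the floor of that step is known, and the evidence for this is the limit of > 800000 nM in this assay, at which 1 of the 2 values shown sits. Going by these compounds, the measured step therefore shows no change beyond the scatter, though its true size remains open. On the strength of that step, with compound 1 at 780000 nM, no step beyond the scatter is expected in this assay, and no direction can be assigned. The expected step is an at least 1.0-fold lower number from compound 2 to compound 3 (0.02 log units; that floor lies within the scatter). For compound 3 the estimated value is 750000 nM, with an expected range from 350000 nM to 1400000 nM.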

Compound 3, half-maximal inhibitory concentration: > 800000 nM
Compound 3: no number, only a limit (the forecaster's own chance of this, stated with the estimate: 40%); at least 1.0-fold (0.02 log units) between middle value and limit.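

In this assay compound 3, which carries plain phenyl on the amide-type nitrogen, gives > 800000 nM, and this is a limit of the assay and not a number. Compound 3 thus sits at the same limit as compound 2, so the chlorine and the nitro group of the 2-chloro-4-nitrophenyl group are not needed to reach it, and the two limits leave the step between these two compounds unreadable. Hydrogen in place of methoxy on an aromatic carbon gives an at least 1.0-fold higher number from compound 1 to compound 3 (0.01 log units; that floor lies within the scatter), so only a floor is known for this change and its true size stays open: the limit of > 800000 nM in this assay, at which 2 of the 3 values shown sit.

The compounds shown leave open what true values lie behind the limits of compound 2 and compound 3, and whether these two compounds differ at all. They also leave open whether an amine or a carboxylic acid on the phenyl ring, or a longer chain between the thiocarbonyl-bearing nitrogen and that ring, would give a readable number in this assay.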